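The compounds below may be only part of what the source reports. "The series", "measured", "known", "first", "only" and "open" are said of these compounds alone.

The series rests on a shared core, and it is followed here in a functional assay on A2058 cells (Homo sapiens) for antiproliferative activity, read by CellTiter-Blue, with a stated time of 24 h; a lower number here means that less compound is needed, a higher number that more compound is needed for the effect. Compound 1 `CS(=O)(=O)c1ccc(C(CCCO[N+](=O)[O-])=C(c2ccc(F)cc2)c2ccc(F)cc2)cc1` belongs to the set, and in this assay compound 1 gives "not determined" (no result reported). Compound 2 `CS(=O)(=O)c1ccc(C(CCCCO[N+](=O)[O-])=C(c2ccc(F)cc2)c2ccc(F)cc2)cc1` likewise belongs to the set, and in this assay compound 2 gives "not determined" (no result reported). Neither of them contributes a number. Among the measured compounds shown here, compound 3 `CS(=O)(=O)c1ccc(C(CCCO)=C(c2ccc(F)cc2)c2ccc(F)cc2)cc1` is the one member with a measured value: in this assay compound 3 gives 27500 nM. Within the numbers shown it therefore stands alone; there is no second value to place it above or below, and no step between measured compounds can be traced.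

Compound 4 `CS(=O)(=O)c1ccc(C(CCCCO)=C(c2ccc(F)cc2)c2ccc(F)cc2)cc1` has not been measured in this assay. It differs from compound 3 in one place: hydroxymethyl in place of hydroxy on a saturated chain carbon, three bonds along the chain from a double-bonded chain carbon. The chain grows by one carbon and the hydroxy group stays at its end.

For the measured compounds named here, with no step between measured compounds to lean on, the expected step from compound 3 to compound 4 is small, a 1.1-fold lower number from compound 3 to compound 4 (0.04 log units; within the scatter), in no fixed direction and not beyond the scatter. Compound 4 is therefore estimated at 25000 nM in this assay, with a range from 8000 nM to 80000 nM.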

Compound 4, half-maximal effective concentration: 39900 nM
For compound 4 the middle estimate is 1.6-fold (0.20 log units) below the measured one; measured number inside the range.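

In this assay, among the compounds shown here, compound 3 and compound 4 form the first pair that can be compared, and hydroxymethyl in place of hydroxy on a saturated chain carbon, three bonds along the chain from a double-bonded chain carbon, gives a 1.5-fold higher number from compound 3 to compound 4 (0.16 log units; within the scatter). The 3-hydroxypropyl chain and the 4-hydroxybutyl chain therefore cannot be told apart in this read-out, so the added carbon, with the hydroxy group kept at the chain's end, has no effect here that stands out from the usual scatter, and neither compound can be ranked above the other. No accompanying measurement bears on this result, so the pair describes the size of the step and nothing about what lies behind it.

Compound 1 and compound 2, which carry a nitrate ester on the chain, have no reported number, so the steps that involve them cannot be read. As far as these compounds go, it remains open whether a longer chain, or an amine or a carboxylic acid in place of the hydroxy group, would move the number beyond the scatter.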